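Sulfamoyl in place of (phenoxymethyl)carbonyl on the amine nitrogen

The source may report more compounds than this note shows. Statements on the series, on what has been measured and on what is new or still open speak of the compounds shown alone.

Measured compounds in an ADME assay on microsomes from liver (Mus musculus) for metabolic stability, read by LC-MS, with NADPH named in the record, with a stated time of 60 min, tested at 1 uM, in the absence of a further agent; a higher number here means that more of the compound is left, a lower number that less of the compound is left:
compound 1 `COc1cc(-c2c(C)nc3c(N4CC[C@@H](NC(C)=O)C4)cc(C)nn23)cc(OC)c1OC`: > 95%
compound 2 `COc1ccc(-c2c(C)nc3c(N4CC[C@@H](NC(C)=O)C4)cc(Cl)nn23)cc1OC`: > 95%
compound 3 `COc1ccc(-c2c(C)nc3c(N4CC[C@@H](NC(=O)COc5ccccc5)C4)cc(C)nn23)cc1OC`: > 95%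

The value of compound 1 in this assay is a limit of the assay, not a number. The value of compound 2 is likewise a limit. The value of compound 3 is also a limit. (the limit of > 95% in this assay, at which 3 of the 3 values shown sit), so the three shown values give no spread at all, and compound 3 can only be said to stand at that limit together with the others; no step between measured compounds can be read from them.

Compound 4 `COc1ccc(-c2c(C)nc3c(N4CC[C@@H](NS(N)(=O)=O)C4)cc(C)nn23)cc1OC` is the one still to be measured in this assay. It differs from compound 3 as follows: sulfamoyl in place of (phenoxymethyl)carbonyl on an amine nitrogen. With every shown value sitting at the limit, there is no measured step on which to rest a direction for this change. The expectation is therefore no step beyond the usual scatter, with some chance that a number somewhat under the limit appears.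

Compound 4 is expected to give 92% in this assay, with a range from 78% to 98%. This estimate corresponds to an expected step of a number at least 3 percentage points lower from compound 3 to compound 4 (that floor lies within the scatter), within the scatter.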

Compound 4, percent of the compound remaining: > 95%
Compound 4 gave a limit, no number; the forecaster's own chance of this, stated with the estimate: 55%; middle value at least 3 percentage points away from the limit.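

Compound 3 and compound 4 both sit at a limit in this assay, so no step between them can be read: the limit of > 95% in this assay, at which 4 of the 4 values shown sit.

The compounds shown leave open whether sulfamoyl in place of (phenoxymethyl)carbonyl, or any other change in this series, alters the percent of compound remaining.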